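This account rests on a few compounds, and the source may have more. Where it says the series, first, only, none or still open, it means among the compounds named here.

Measured in a functional assay on MCF7 cells (Homo sapiens) for antiproliferative activity; a higher number here means a weaker inhibitor, a lower number a stronger inhibitor:
- Compound 1 `CC(C)=CCCC1=CC[C@H](C(=O)Nc2ccc(O)cc2)[C@@H](c2ccccc2)C1`: 66700 nM
- Compound 2 `CON(C)C(=O)[C@H]1CC=C(CCC=C(C)C)C[C@@H]1c1ccccc1`: 42100 nM
- Compound 3 `CC(C)=CCCC1=CC[C@H](C(=O)O)[C@@H](c2ccccc2)C1`: 64300 nM

Compound 3 sits within the scatter of both other compounds, so the three cannot be ranked. Compound 4 `CONC(=O)[C@H]1CC=C(CCC=C(C)C)C[C@@H]1c1ccccc1` has methoxyamino in place of hydroxy on a carbonyl carbon.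

Three measured steps change the group at this carbonyl carbon: a 1.6-fold lower number from compound 1 to compound 2 (0.20 log units; within the scatter), a 1.0-fold lower number from compound 1 to compound 3 (0.02 log units; within the scatter) and a 1.5-fold higher number from compound 2 to compound 3 (0.18 log units; within the scatter). The last is the closest guide, as it involves methoxy(methyl)amino and hydroxy. None exceeds the scatter, so no step beyond the scatter is expected in this assay. The expected change is a 1.3-fold lower number from compound 3 to compound 4 (0.11 log units; within the scatter). For compound 4, the estimated value is 50000 nM, with an expected range of 25000 nM to 100000 nM.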

Compound 4, half-maximal inhibitory concentration: 45200 nM
Beside the measured number, compound 4's estimate is 1.1-fold (0.04 log units) above it; measured number inside the range.
By their numbers in this assay, from the lowest: compounds 2, 4, 3 and 1 (each within the scatter of the next).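

In this assay, methoxyamino on this carbonyl carbon cannot be told apart from hydroxy, with a 1.4-fold lower number from compound 3 to compound 4 (0.15 log units; within the scatter) for that swap. The amide-type nitrogen adds little: hydrogen in place of methyl gives a 1.1-fold higher number from compound 2 to compound 4 (0.03 log units; within the scatter) and methoxy in place of 4-hydroxyphenyl gives a 1.5-fold lower number from compound 1 to compound 4 (0.17 log units; within the scatter) as its step. All four groups on this carbonyl carbon therefore stay within the scatter of one another, so the amide hydrogen makes no readable difference.

No available data offer a reason for this. As far as these compounds go, whether a plain amino group, a longer alkyl chain on the nitrogen or a change elsewhere on the shared core would give a step beyond the scatter remains open.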